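This account rests on a few compounds, and the source may have more. Where it says the series, first, only, none or still open, it means among the compounds named here.

Among the compounds with values here, in a functional assay on Shh Light II cells (Mus musculus) for inhibition, read by a luciferase reporter (on this read-out higher numbers stand for weaker inhibition and lower numbers for stronger inhibition), compound 2 `O=C(NC1CC[S+]([O-])CC1)N1CCC(c2nc(-c3ccc4ccccc4n3)no2)CC1` gives 850 nM, the higher of the two numbers so far, while compound 1 `O=C(NC1CCS(=O)(=O)CC1)N1CCC(c2nc(-c3ccc4ccccc4n3)no2)CC1` gives 360 nM. Compound 3 `COc1ccccc1N(C)C(=O)N1CCC(c2nc(-c3ccc4ccccc4n3)no2)CC1` has not been measured, and its structure differs from that of compound 2 as follows: a group of 10 heavy atoms (8 carbon, 1 nitrogen, 1 oxygen; one six-membered aromatic ring of carbon only) in place of a group of 8 heavy atoms (5 carbon, 1 nitrogen, 1 oxygen, 1 sulfur; one six-membered non-aromatic ring with 1 hetero atom), on a carbonyl carbon. Within the data shown here, the only measured step at this place, a 2.4-fold higher number from compound 1 to compound 2 (0.37 log units; beyond the scatter), is modest and keeps the non-aromatic ring. Among the measured compounds shown here, no measured compound carries an aromatic ring here, so the guide is weak. A modest move to a lower number is expected, a 4.3-fold lower number from compound 2 to compound 3 (0.63 log units; beyond the scatter). For compound 3 the estimated value is 200 nM, with an expected range of 30 nM to 1000 nM.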

Compound 3, half-maximal inhibitory concentration: 3100 nM
Compound 3: the middle estimate sits 16-fold (1.19 log units) below what was measured, outside the stated range (above it).
By their numbers in this assay, from the lowest: compound 1; then compound 2; then compound 3.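

In this assay, within the data shown here, the (2-methoxyphenyl)(methyl)amino group on the carbonyl carbon, the only group here with an aromatic ring and without a hydrogen-bond donor, gives a 3.6-fold higher number from compound 2 to compound 3 (0.56 log units; beyond the scatter) and an 8.6-fold higher number from compound 1 to compound 3 (0.94 log units; beyond the scatter) as well. This aromatic group therefore brings no lower number at this place, and it stands behind both non-aromatic rings. Nothing available here bears on why the number rises. The compounds shown leave open whether the rise follows the aromatic ring itself or the methyl on the nitrogen. They also leave open where a plain phenylamino group or a (1-methylpiperidin-4-yl)amino group would fall.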